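Swapping methylamino for methoxy on a carbonyl carbon

This account rests on a few compounds, and the source may have more. Where it says the series, first, only, none or still open, it means among the compounds named here.

In a functional assay on PANC-1 cells (Homo sapiens) for cytotoxicity, with a stated time of 7 days (a lower number here means a stronger inhibitor, a higher number a weaker inhibitor), compound 1 `CC(C)=CCC/C(C)=C/CC/C(C)=C/CSc1ccccc1C(=O)OC(C)C` gives 70000 nM, while compound 2 `CNC(=O)c1ccccc1SC/C=C(\C)CC/C=C(\C)CCC=C(C)C` gives 10000 nM, the lower number of the two. Compound 3 `COC(=O)c1ccccc1SC/C=C(\C)CC/C=C(\C)CCC=C(C)C` shares the rest of its structure with compound 2 and differs at one place: methoxy in place of methylamino on a carbonyl carbon. Put simply, methoxy takes the place of methylamino on a carbonyl carbon. Among the compounds with values here, the only measured step that bears on this is a 7.0-fold lower number from compound 1 to compound 2 (0.85 log units; beyond the scatter), with methylamino in place of isopropoxy on a carbonyl carbon. Compound 3 thus loses the methylamino, and its methoxy resembles the isopropoxy of compound 1 without matching it. Within the data shown here, no measurement yet separates those two groups, and a single step is thin evidence. The expected change in this assay is a 3.5-fold higher number from compound 2 to compound 3 (0.54 log units; beyond the scatter), toward a higher number and probably smaller than the measured step. For compound 3 the estimated value is 35000 nM, with an expected range from 12000 nM to 100000 nM.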

Compound 3, half-maximal inhibitory concentration: 30000 nM
Compound 3: middle estimate off by 1.2-fold (0.07 log units), on the high side, within the range that was stated.
By their numbers in this assay, from the lowest: compound 2; then compound 3; then compound 1.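

In this assay, methylamino gives a lower number than methoxy on this carbonyl carbon, with methoxy in its place producing a 3.0-fold higher number from compound 2 to compound 3 (0.48 log units; beyond the scatter), so the earlier advantage over isopropoxy was not specific to that one group. The group on the oxygen next to the carbonyl group also matters, as methyl in place of isopropyl gives a 2.3-fold lower number from compound 1 to compound 3 (0.37 log units; beyond the scatter), and methylamino still gives the lowest number of the three compounds. No measurement shown here explains either step.

On these data alone, it remains open whether a plain amino group, an ethylamino group or a carboxylic acid on the same carbonyl carbon would continue this order. The long chain is the same in all three compounds, so it is also unknown whether these steps would hold with a shorter chain.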